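The compounds below may be only part of what the source reports. "The series", "measured", "known", "first", "only" and "open" are said of these compounds alone.

Measured compounds in this study:
compound 1, `C#CCN(c1nc(-c2cccc(C)c2)no1)C1CCCCC1`: 44.4 ug/mL
compound 2, `CC(=O)OC[C@H]1O[C@H](OC[C@@H](Cn2cc(CN(c3nc(-c4ccccc4)no3)C3CCCCC3)nn2)OC(C)=O)C=C[C@@H]1OC(C)=O`: 19.9 ug/mL
compound 3, `C#CCN(c1nc(-c2ccc(Cl)cc2)no1)C1CCCCC1`: 41.3 ug/mL

All three values come from an ADME assay on HepG2 cells (Homo sapiens) for cytotoxicity, read by MTT assay, with a stated time of 48 h; on this read-out higher numbers stand for lower toxicity in this test and lower numbers for higher toxicity in this test. Compound 3 stands second highest of the three numbers; compound 1 is within the scatter of it, while compound 2, at 19.9 ug/mL, gives a lower number, beyond the scatter. Compound 4, `C#CCN(c1nc(-c2ccc(C(F)(F)F)cc2)no1)C1CCCCC1`, differs from compound 3 by trifluoromethyl in place of chloro on an aromatic carbon. For the measured compounds named here, the one measured step between related compounds, a 1.1-fold lower number from compound 1 to compound 3 (0.03 log units; within the scatter), swapped one group on the same aromatic ring for another and stayed within the scatter; no measured step exchanges chloro for trifluoromethyl. On that basis the step for compound 4 is expected to be small, a 1.1-fold lower number from compound 3 to compound 4 (0.04 log units; within the scatter), with no change beyond the scatter. The estimate for compound 4 is 38 ug/mL, expected between 20 ug/mL and 70 ug/mL.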

Compound 4, half-maximal cytotoxic concentration: 61.9 ug/mL
For compound 4 the middle estimate is 1.6-fold (0.21 log units) below the measured one, and the stated range covers the measured number.
By their numbers in this assay, from the lowest: compound 2; then compounds 3, 1 and 4 (each within the scatter of the next).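

In this assay, trifluoromethyl in place of chloro on this aromatic carbon, para to a large group, gives a 1.5-fold higher number from compound 3 to compound 4 (0.18 log units; within the scatter). For the compounds shown here, this is the first step to exchange these two groups at this place, and a larger group here leaves the number within the scatter of compound 3. So, in this one pair, the change does not separate the two compounds on this read-out.

From the compounds shown here alone, what an amine or a carboxylic acid at this same place would do to the number remains open. No measurement is available that explains this result.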